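Chloro in place of hydrogen on a weakly active scaffold

A few compounds are considered here, and "the series" means these few. Any claim that something is new, unique, unknown or untested is made for them only; others in the source may bear on it.

Compound 1 `COc1ncc(-c2ccc3c(c2)N(c2ccc(C)cc2)C(=O)CO3)cc1NS(=O)(=O)c1ccc(F)cc1` — in a functional assay on HCT-116 cells (Homo sapiens) for antiproliferative activity, read by MTT assay, with a stated time of 72 h (a lower number here means a stronger inhibitor, a higher number a weaker inhibitor), compound 1 gives 22700 nM.
Compound 3 `COc1ccc(N2C(=O)COc3ccc(-c4cnc(OC)c(NS(=O)(=O)c5ccc(F)cc5)c4)cc32)cc1` — compound 3 gives 13400 nM.
Compound 2 `O=C1COc2ccc(-c3cccc(NS(=O)(=O)c4ccc(F)cc4)c3)cc2N1c1ccccc1` — compound 2 is reported only as a limit of this assay, > 40000 nM.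

Compound 2 therefore stands at the weak end of what has been measured; it sits at the limit of > 40000 nM in this assay, at which 1 of the 3 values shown sits, and no number is known for it. Compound 4 `O=C1COc2ccc(-c3cccc(NS(=O)(=O)c4ccc(F)cc4)c3)cc2N1c1ccc(Cl)cc1` differs from compound 2 by chloro in place of hydrogen on an aromatic carbon. Among the compounds with values here, the only measured step of a related kind, a 1.7-fold lower number from compound 1 to compound 3 (0.23 log units; within the scatter), is within the scatter, so no step beyond the scatter is expected in this assay for compound 4 either: the expected step is an at least 1.1-fold lower number from compound 2 to compound 4 (0.05 log units; that floor lies within the scatter). Compound 4 is expected to give about 35000 nM, between 15000 nM and 80000 nM, most likely again reported only as a limit.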

Compound 4, half-maximal inhibitory concentration: 23900 nM
Beside the measured number, compound 4's estimate is 1.5-fold (0.17 log units) above it; low and high end bracket the measured number.
By their numbers in this assay, from the lowest: compounds 3, 1 and 4 (each within the scatter of the next). At a limit, above all of these: compound 2.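

Compound 2 is held only at a limit of this assay, > 40000 nM. Within the data shown here, with phenyl changed to 4-chlorophenyl, compound 4 is the first compound on this core to give a number rather than a limit, which places chloro on a carbon para to a large group within the range of the assay. The change is bounded on one side only, as an at least 1.6-fold lower number from compound 2 to compound 4 (0.22 log units; that floor lies within the scatter), so a step beyond the scatter is neither shown nor excluded.

As far as these compounds go, what an amine or a carboxylic acid would give at this position stays open. So does whether chloro would act alike on the core of compound 1.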